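Naphthalen-1-yl in place of 4-(tert-butyl)phenyl: Vero cell outlook

This account rests on a few compounds, and the source may have more. Where it says the series, first, only, none or still open, it means among the compounds named here.

Compound 1, `CSc1ccc(C(=O)/C(=C/c2ccccn2)c2ccc(Cl)c(Cl)c2)cc1`, gives 89.6%.
Compound 2, `CCOC(=O)C(C(=O)c1ccc(OC)cc1)C(NC(C)=O)c1ccc(C(C)C)cc1`, gives 90.4%.
Compound 3, `CCOC(=O)C(C(=O)c1ccc(OC)cc1)C(NC(C)=O)c1ccc(C(C)(C)C)cc1`, gives 89.5%.

All three numbers come from an ADME assay on Vero cells (Chlorocebus sabaeus) for cytotoxicity, read by MTT assay, tested at 100 uM; a higher number here means a weaker effect of the compound at the concentration tested, a lower number a stronger effect. Compound 3 shows the lowest of the three numbers, but its gaps to compound 1 and compound 2 both lie within the scatter, so the three compounds cannot be told apart on this read-out.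

Going by the values given here, the only measured step, a number 0.9 percentage points lower from compound 2 to compound 3 (within the scatter), is within the scatter; it shares with the new step the same place of change on the ring bound to the amide-bearing chain carbon, and it is the only guide available.

Compound 4, `CCOC(=O)C(C(=O)c1ccc(OC)cc1)C(NC(C)=O)c1cccc2ccccc12`, is not yet measured. Compared with compound 3 it carries naphthalen-1-yl in place of 4-(tert-butyl)phenyl on a saturated chain carbon bound to an amide-type nitrogen and a saturated chain carbon. Among the compounds with values here, with one flat step as the only precedent, a step within the scatter is expected, a number 1.5 percentage points lower from compound 3 to compound 4 (within the scatter). Compound 4 is therefore estimated at 88%, with a range from 78% to 97%.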

Compound 4, a percentage reported as activity, at one concentration (the size of the read-out at that concentration, not a potency): 95.5%
Beside the measured number, compound 4's estimate is 7.5 percentage points below it; measured number inside the range.
By their numbers in this assay, from the lowest: compounds 3, 1, 2 and 4 (each within the scatter of the next).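

In this assay, naphthalen-1-yl in place of 4-(tert-butyl)phenyl gives a number 6 percentage points higher from compound 3 to compound 4 (within the scatter), and naphthalen-1-yl in place of 4-isopropylphenyl gives a number 5.1 percentage points higher from compound 2 to compound 4 (within the scatter). The earlier step at this place only exchanged one alkyl-bearing phenyl group for another, whereas these steps bring in a second six-membered aromatic ring while keeping 10 heavy atoms against 4-(tert-butyl)phenyl, and the read-out still cannot separate the compounds. No measurement is available to explain these small differences.

The compounds shown leave open whether a ring carrying an amine or a carboxylic acid on the same saturated chain carbon would also stay within the scatter. They also leave open how a group with hydrogen-bond donors or acceptors at this place would read in this assay.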